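A few compounds are considered here, and "the series" means these few. Any claim that something is new, unique, unknown or untested is made for them only; others in the source may bear on it.

Measured in a physicochemical assay for solubility, in phosphate buffer, measured as kinetic solubility, with a stated time of 24 h, at pH 7.4; a lower number here means a less soluble compound, a higher number a more soluble compound; each value is a limit:
- compound 1 `CC(C)CN(Cc1ccc(N2CCN(S(C)(=O)=O)CC2)cc1)S(=O)(=O)Cc1ccccc1`: <= 1000 nM
- compound 2 `CC(C)CN(Cc1ccc(N2CCC(C(N)=O)CC2)cc1)S(=O)(=O)Cc1ccccc1`: <= 1000 nM
- compound 3 `CC(=O)N1CCN(c2ccc(CN(CC(C)C)S(=O)(=O)Cc3ccccc3)cc2)CC1`: <= 1000 nM

In this assay, compound 3 is known only as a limit, <= 1000 nM. The series offers no number to start from, as all three compounds sit at the limit of <= 1000 nM in this assay, at which 3 of the 3 values shown sit.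

Compound 4 `CC(=O)N1CCN(c2ccc(CN(C(C)C)S(=O)(=O)Cc3ccccc3)cc2)CC1` differs from compound 3 by isopropyl in place of isobutyl on a sulfonamide nitrogen. Within the data shown here, none of the measured steps changes that place, and all three have no readable size: a step that the two limits leave unreadable from compound 1 to compound 2, a step that the two limits leave unreadable from compound 1 to compound 3 and a step that the two limits leave unreadable from compound 2 to compound 3. They therefore give no guide to size or direction, and no shift beyond the scatter can be argued from them. What is expected is a step that the limit leaves unreadable from compound 3 to compound 4, with neither direction favoured. A report as a limit again is the likeliest outcome. For compound 4 the estimate is 700 nM, with an expected range from 250 nM to 1500 nM.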

Compound 4, solubility: <= 1000 nM
Compound 4: only a limit was reported; the forecaster's own chance of this, stated with the estimate: 80%; the middle value does not contradict the limit.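

Compound 3 and compound 4 are both reported in this assay only as limits, so no step between them can be read, and all the compounds shown share one limit: the limit of <= 1000 nM in this assay, at which 4 of the 4 values shown sit.

The compounds shown leave open where any of their solubilities actually lies, and whether isopropyl in place of isobutyl on a sulfonamide nitrogen shifts it at all.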